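Swapping One Chlorine for Hydrogen in a Rapidly Cleared Compound

The source may hold more compounds than are shown below. What is called first, only, known or untested is meant among the compounds shown, and "the series" means these compounds.

For the measured compounds named here, in an in vitro ADME assay on microsomes from liver (Homo sapiens) for metabolic stability, tested at 0.2 uM (a higher number here means faster removal of the compound, a lower number slower removal), compound 1 (`O=c1c(Cl)c(COc2cccc(OCC3CCOCC3)c2)[nH]c2ccccc12`) gives 460 mL/min/kg and this is the only exact number so far. Compound 2 (`CCCCCCCCCc1[nH]c2ccccc2c(=O)c1C`) reads > 1000 mL/min/kg and that is a limit of the assay, not a number. The next compound to be tested is compound 3 (`O=c1cc(COc2cccc(OCC3CCOCC3)c2)[nH]c2ccccc12`), which differs from compound 1 in one place, with hydrogen in place of chloro on an aromatic carbon sets out what is counted in this swap. Going by the values given here, no measured pair yet shows what such a swap does in this assay and so no large shift in clearance can be argued for. The expected step of a 1.2-fold lower number from compound 1 to compound 3 (0.06 log units; within the scatter) is a slight fall that stays within the usual scatter of repeated measurements. Compound 3 is estimated at 400 mL/min/kg with a likely range from 180 mL/min/kg to 850 mL/min/kg in this measurement.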

Compound 3, clearance in the Homo sapiens assay: 78 mL/min/kg
Estimate against measurement, compound 3: 5.1-fold (0.71 log units) above, and the stated range ends above it.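

In the Homo sapiens assay compound 1 gives 460 mL/min/kg and compound 3 gives 78 mL/min/kg. With hydrogen in place of chloro on this aromatic carbon, the Homo sapiens assay shows a 5.9-fold lower number from compound 1 to compound 3 (0.77 log units; beyond the scatter) and so gives the first measured sign that this one position matters for how fast the compound is removed. The change takes away a single heavy atom, one chlorine, and still the step lies beyond the usual scatter. In a physicochemical assay for solubility, at pH 6.8 (on this read-out higher numbers stand for higher solubility and lower numbers for lower solubility), compound 1 gives 2000 nM and compound 3 gives 4000 nM. In the physicochemical assay the same swap gives a 2.0-fold higher number from compound 1 to compound 3 (0.30 log units; within the scatter) and so the two compounds cannot be told apart on that read-out.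

Nothing measured here says why removal changes with this swap. Going by these compounds, whether another group at this position, such as fluoro, methyl or a nitrile, would behave more like hydrogen or more like chloro remains open, as does whether the same swap would have a similar effect on a different core.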